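Swapping nitro for methoxy on the urea-side phenyl

The source may report more compounds than this note shows. Statements on the series, on what has been measured and on what is new or still open speak of the compounds shown alone.

Measured compounds in a functional assay on RS4-11 cells (Homo sapiens) for inhibition, read by CCK-8 assay, with a stated time of 48 h; on this read-out higher numbers stand for weaker inhibition and lower numbers for stronger inhibition:
compound 1, `O=S(=O)(NCCNC(=S)Nc1ccc(Cl)cc1)c1ccc(-c2ccccc2OCc2ccccc2)s1`, > 50000 nM
compound 2, `Cc1ccc(-c2ccsc2S(=O)(=O)NCCNC(=O)Nc2cccc([N+](=O)[O-])c2)c(Oc2ccc(O)c(O)c2)c1`, 9100 nM
compound 3, `Cc1ccc(-c2ccsc2S(=O)(=O)NCCNC(=O)Nc2ccc([N+](=O)[O-])cc2)c(Oc2ccc(O)c(O)c2)c1`, 7700 nM

Three compounds share a sulfonamide-linked core, and two of them carry a nitrophenyl urea at the far end. Compound 3 gives 7700 nM in this assay. Among the compounds with values here, compound 2 sits close to it, and the only single-point comparison between measured compounds, 4-nitrophenyl in place of 3-nitrophenyl on an amide-type nitrogen, gives a 1.2-fold lower number from compound 2 to compound 3 (0.07 log units; within the scatter). The value of compound 1 in this assay is a limit, (the limit of > 50000 nM in this assay, at which 1 of the 3 values shown sits), not a number, and compound 1 differs from the others in several places at once.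

Compound 4, `COc1ccc(NC(=O)NCCNS(=O)(=O)c2sccc2-c2ccc(C)cc2Oc2ccc(O)c(O)c2)cc1`, keeps everything of compound 3 except for (methoxy in place of nitro on an aromatic carbon). No measured step bears directly on this change; the one step shown moved the nitro group around the ring and stayed within the scatter. There is therefore no basis for expecting a step beyond the scatter, in either direction. Compound 4 is expected to give 10000 nM, with a range from 3000 nM to 35000 nM, which is expected to correspond to a 1.3-fold higher number from compound 3 to compound 4 (0.11 log units; within the scatter).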

Compound 4, half-maximal inhibitory concentration: 8200 nM
Beside the measured number, compound 4's estimate is 1.2-fold (0.09 log units) above it; low and high end bracket the measured number.
By their numbers in this assay, from the lowest: compounds 3, 4 and 2 (each within the scatter of the next). At a limit, above all of these: compound 1.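

In this assay, the earlier step only moved the nitro group around the ring, so it could not show what happens when the group itself is replaced. Here nitro gives way to methoxy, a group with different atoms and fewer hydrogen-bond acceptors, on the same aromatic carbon para to a large group, and the result is a 1.1-fold higher number from compound 3 to compound 4 (0.03 log units; within the scatter). Compared with the 3-nitrophenyl urea, the result is the same in kind, a 1.1-fold lower number from compound 2 to compound 4 (0.05 log units; within the scatter), so on the evidence of these three compounds, neither the identity of this group nor the two nitro positions shifts the number beyond the scatter.

Nothing among the data shown accounts for why the number holds across this exchange. From the compounds shown here alone, it remains open whether a different kind of group at this same place, such as an amine, a carboxylic acid or simply a hydrogen in place of the substituent, would give a step beyond the scatter, or whether the phenyl ring could carry a longer chain without any such step.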